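The source may report more compounds than this note shows. Statements on the series, on what has been measured and on what is new or still open speak of the compounds shown alone.

Measured so far:
compound 1 `COc1ccc(NC2=CC(=O)c3c(nc4n3[C@H]3OC[C@@H](O)[C@H]3OC4)C2=O)cc1` — in a functional assay on ECa-109 cells for inhibition, with ECa-109 cell line (Homo sapiens) as the target, read by sulforhodamine B assay (a higher number here means a weaker inhibitor, a lower number a stronger inhibitor), compound 1 gives 3410 nM
compound 2 `O=C1C=C(Nc2ccccc2)C(=O)c2c1nc1n2[C@H]2OC[C@@H](O)[C@H]2OC1` — compound 2 gives 4970 nM
compound 3 `CCCc1ccc(NC2=CC(=O)c3nc4n(c3C2=O)[C@H]2OC[C@@H](O)[C@H]2OC4)cc1` — compound 3 gives only a limit, > 4000 nM

Compound 1 holds the lowest of the two numbers, but compound 2 sits within the scatter of it, so no order between them is claimed. Among the compounds with values here, the only step between measured compounds, a step that the limit leaves unreadable from compound 2 to compound 3, cannot be read because of the limit of > 4000 nM in this assay, at which 1 of the 3 values shown sits.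

Compound 4 `O=C1C(N2CCC2)=CC(=O)c2c1nc1n2[C@H]2OC[C@@H](O)[C@H]2OC1` differs from compound 1 in one place: azetidin-1-yl in place of (4-methoxyphenyl)amino on a double-bonded ring carbon. Within the data shown here, no measured step touches this change, and the one step available is unreadable, so no direction beyond the scatter is inferred from the data. Compound 4 is therefore expected to give 5000 nM, roughly between 1500 nM and 16000 nM. The expected step is a 1.5-fold higher number from compound 1 to compound 4 (0.17 log units; within the scatter).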

Compound 4, half-maximal inhibitory concentration: > 16000 nM
Compound 4: no number, only a limit (the forecaster's own chance of this, stated with the estimate: 35%); middle value at least 3.2-fold (0.50 log units) from the limit.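

In this assay compound 4 gives only a limit, > 16000 nM. Even so, the change at this double-bonded ring carbon can be read as an at least 4.6-fold higher number from compound 1 to compound 4 (0.67 log units; beyond the scatter), which makes azetidin-1-yl in place of (4-methoxyphenyl)amino the only change shown with a readable direction. Its size remains open-ended: the limit of > 16000 nM in this assay, at which 1 of the 4 values shown sits.

The compounds shown leave open whether the aromatic ring or the amine hydrogen matters more here. Cyclohexylamino, which keeps that hydrogen without the aromatic ring, and piperidin-1-yl, a larger ring amine, would help separate the two.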